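The source may report more compounds than this note shows. Statements on the series, on what has been measured and on what is new or still open speak of the compounds shown alone.

Measured compounds and their values:

Compound 1 `COc1nc(=O)n(C)c(CC(F)(COC(C)=O)COC(C)=O)c1C`: > 100000 nM
Compound 2 `COc1nc(=O)n(C)c(CC(O)(COC(C)=O)COC(C)=O)c1C`: > 100000 nM
Compound 3 `CC(=O)OCC(O)(COC(C)=O)Cc1c(C)c(=O)[nH]c(=O)n1C`: > 100000 nM

All three compounds were tested in a functional assay on MCF7 cells (Homo sapiens) for antiproliferative activity, read by MTT assay, with a stated time of 72 h; a lower number here means a stronger inhibitor, a higher number a weaker inhibitor. Each of the three values is a limit of the assay rather than a number: in this assay compound 1 gives > 100000 nM. In the same assay compound 2 gives > 100000 nM. Compound 3 likewise gives > 100000 nM. All three therefore sit at one and the same limit, (the limit of > 100000 nM in this assay, at which 3 of the 3 values shown sit).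

Compound 2 and compound 1 share a core and differ in one place only, (fluoro in place of hydroxy on a saturated chain carbon bound to three saturated chain carbons). The step this change made, a step that the two limits leave unreadable from compound 2 to compound 1, cannot be read, since both ends are limits.

Compound 3 has a different core; how the two cores differ is not broken down here. Compound 4 `CC(=O)OCC(F)(COC(C)=O)Cc1c(C)c(=O)[nH]c(=O)n1C` differs from compound 3 by fluoro in place of hydroxy on a saturated chain carbon bound to three saturated chain carbons. The place is described in the same words as for the change from compound 2 to compound 1, so this is the same change carried out on a second core.

The expectation for compound 4 rests on two points: compound 3 gives only a limit in this assay, and the same change elsewhere gave the unreadable step that the two limits leave unreadable from compound 2 to compound 1. Compound 4 is thus expected to show a step that the limit leaves unreadable from compound 3 to compound 4. Compound 4 is estimated at 150000 nM, with a range from 40000 nM to 600000 nM, and the assay is expected most likely to report only a limit again.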

Compound 4, half-maximal inhibitory concentration: > 100000 nM
Compound 4: no number, only a limit (the forecaster's own chance of this, stated with the estimate: 85%); the middle value is on the limit's open side.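

Compound 3 and compound 4 both give a limit of the assay rather than a number, so the size of the step between them cannot be read: the limit of > 100000 nM in this assay, at which 4 of the 4 values shown sit. The compounds shown leave open whether fluoro in place of hydroxy changes activity at all in this assay, on either core, and which structural features would bring a measurable value.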